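Swapping 2-fluorophenyl for 3-fluorophenyl in a small series

The source may hold more compounds than are shown below. What is called first, only, known or untested is meant among the compounds shown, and "the series" means these compounds.

In an ADME assay on HUVEC cells (Homo sapiens) for inhibition, read by CCK-8 assay, with a stated time of 24 h, in the presence of a further agent that is not named here (on this read-out lower numbers stand for stronger inhibition and higher numbers for weaker inhibition), compound 1 (`O=C1Nc2ccccc2/C1=C/c1ccc(-c2cn(-c3cccc(F)c3)nn2)cc1`) gives only a limit, > 20000 nM and no number. Among the compounds with values here, compound 2 (`O=C1Nc2ccc(F)cc2/C1=C/c1ccc(-c2cn(-c3ccccc3F)nn2)cc1`) reads 14400 nM in this assay and so holds the only actual number so far. Compound 3 (`O=C1Nc2ccc(F)cc2/C1=C/c1ccc(-c2cn(-c3cccc(F)c3)nn2)cc1`) has not yet been measured. It has the same atoms as compound 2 but carries 3-fluorophenyl in place of 2-fluorophenyl on an aromatic nitrogen of a five-membered aromatic ring with 3 nitrogen. Within the data shown here, no pair of measured compounds isolates this change, so the data give no direct size for it. The 3-fluorophenyl group also sits on compound 1, whose > 20000 nM is a limit. A small step is therefore expected in this assay, toward weaker inhibition if there is any movement, and perhaps none beyond the usual scatter. The estimated move is a 1.1-fold higher number from compound 2 to compound 3 (0.05 log units; within the scatter) and stays small. For compound 3 the expected value is 16000 nM with an estimated range from 8000 nM to 25000 nM as the likely span.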

Compound 3, half-maximal inhibitory concentration: 17300 nM
Estimate against measurement, compound 3: 1.1-fold (0.03 log units) below; low and high end bracket the measured number.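

The pair gives the first direct size for 3-fluorophenyl in place of 2-fluorophenyl on an aromatic nitrogen. In this assay the step is a 1.2-fold higher number from compound 2 to compound 3 (0.08 log units; within the scatter), so the two groups are not told apart at this place. The new value also makes fluoro in place of hydrogen on an aromatic carbon of the shared core readable, but only as a floor: with an at least 1.1-fold lower number from compound 1 to compound 3 (0.06 log units; that floor lies within the scatter), it establishes no real gain. Compound 1 carries a limit and no number, so this step has a bound on one side only: the limit of > 20000 nM in this assay, at which 1 of the 3 values shown sits.

From the compounds shown here alone, all three compounds carry a fluoro on the phenyl group at the aromatic nitrogen, so it remains open how this place would read with an amine or a carboxylic acid in place of that fluoro. Going by these compounds, it also remains open whether the fluoro on the shared core would have any larger effect with 2-fluorophenyl in place of 3-fluorophenyl, or with a longer chain at the aromatic nitrogen.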